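From propargyl to but-2-yn-1-yl in compound 1

The source may report more compounds than this note shows. Statements on the series, on what has been measured and on what is new or still open speak of the compounds shown alone.

Measured in an ADME assay (liver) for metabolic stability, with Liver microsome (Rattus norvegicus) as the target, using microsomes and NADPH, with a stated time of 30 min (a higher number here means faster removal of the compound, a lower number slower removal), so far
Compound 1 `C#CCC(O)(c1ccc(N2CCN(S(=O)(=O)c3ccc(N)nc3)C[C@@H]2C#CC)cc1)C(F)(F)F` (59 mL.min-1.g-1)
Compound 2 `CC#C[C@H]1CN(S(=O)(=O)c2ccc(N)nc2)CCN1c1ccc(C(C)(O)C(F)(F)F)nc1` (31 mL.min-1.g-1)

Compound 1 and compound 2 lie within the scatter of each other, so compound 1 does not stand apart in this assay on these two numbers. Compound 3 `CC#CCC(O)(c1ccc(N2CCN(S(=O)(=O)c3ccc(N)nc3)C[C@@H]2C#CC)cc1)C(F)(F)F` keeps the core of compound 1 but has methyl in place of hydrogen on a triple-bonded carbon, which turns propargyl into but-2-yn-1-yl. Going by the values given here, no measured pair shows this change, so no step beyond the scatter is expected in this assay, and no direction can be firmly called. The estimated step (a 1.1-fold higher number from compound 1 to compound 3 (0.04 log units; within the scatter)) is expected to stay small. For compound 3 the expected value is an estimated 65 mL.min-1.g-1 (range 32 mL.min-1.g-1 to 130 mL.min-1.g-1).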

Compound 3, intrinsic clearance in microsomes: 115 mL.min-1.g-1
For compound 3 the middle estimate is 1.8-fold (0.25 log units) below the measured one, within the range that was stated.
By their numbers in this assay, from the lowest: compounds 2, 1 and 3 (each within the scatter of the next, the first and the last beyond it).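

Methyl in place of hydrogen on a triple-bonded carbon, which turns propargyl into but-2-yn-1-yl, now has one measured pair in this assay, and that pair gives a 1.9-fold higher number from compound 1 to compound 3 (0.29 log units; within the scatter) as its step. At this position, then, the added methyl does not carry the number beyond the scatter in this single pair. Nothing available bears on the reason for this result.

The compounds shown leave open whether a longer chain or an amine at this place would give a step beyond the scatter. They also leave open whether the same change behaves alike on another core.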